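This account rests on a few compounds, and the source may have more. Where it says the series, first, only, none or still open, it means among the compounds named here.

Measured so far:
- compound 1 `O=C1C=C[C@@H](OC2CCCC2)O[C@@H]1CO`: 8000 nM
- compound 2 `O=C1C=C[C@@H](OC2CCCCC2)O[C@@H]1CO`: 7500 nM

In a functional assay on HEp-2 cells (Homo sapiens) for inhibition, read by MTT assay, with a stated time of 72 h (on this read-out higher numbers stand for weaker inhibition and lower numbers for stronger inhibition), compound 1 gives 8000 nM and compound 2 gives 7500 nM. These two values lie within the usual scatter of each other, so compound 1 cannot be ranked against compound 2, and the series has no measured spread beyond that scatter.

Compound 3 `CC(C)O[C@@H]1C=CC(=O)[C@@H](CO)O1` keeps the core of compound 1 and has isopropyl in place of cyclopentyl on an oxygen on a saturated carbon. For the measured compounds named here, no measured pair isolates this exchange, so the expectation rests only on the two values in hand, which sit close together. A large step in this assay is not expected. The expected outcome is no step beyond the scatter, with a slight lean towards a higher number, meaning weaker inhibition. The estimated change is a 1.3-fold higher number from compound 1 to compound 3 (0.10 log units; within the scatter). For compound 3 the estimated value is 10000 nM, with an expected range from 5000 nM to 25000 nM.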

Compound 3, half-maximal inhibitory concentration: 34900 nM
Compound 3: middle estimate off by 3.5-fold (0.54 log units), on the low side; measured number above the stated range.
By their numbers in this assay, from the lowest: compounds 2 and 1 (each within the scatter of the next); then compound 3.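

In this assay, for the compounds shown here, isopropyl in place of cyclopentyl on an oxygen on a saturated carbon brings a 4.4-fold higher number from compound 1 to compound 3 (0.64 log units; beyond the scatter) and is the first step beyond the scatter, whereas compound 1 and compound 2, with cyclopentyl and cyclohexyl, could not be separated. This position is therefore not indifferent to every exchange of one carbon-only group for another: the change removes the ring and leaves a smaller group, with hydrogen-bond donor and acceptor counts unchanged at zero on both sides. No measurement at hand accounts for this step, which rests on a single pair.

Still open, from the compounds shown here alone, is whether the ring itself or only the number of carbons goes with the stronger inhibition, a question that an open chain of similar size to cyclopentyl, such as n-pentyl, could separate from the ring. Also open, going by these compounds, is how this position responds to groups carrying a heteroatom, such as an amine or a carboxylic acid, and whether a larger ring such as cycloheptyl would stay level with cyclopentyl and cyclohexyl.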